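Cytotoxicity notes: biaryl amide series, nitrophenyl replacement

The source may hold more compounds than are shown below. What is called first, only, known or untested is meant among the compounds shown, and "the series" means these compounds.

Measured so far:
Compound 1, `CCOC(=O)CCCCCOc1cccc(CN(C(=O)c2ccc(-c3ccc4c(c3)OCCO4)cc2)C(C)C)c1`; in an ADME assay on HEK293 cells (Homo sapiens) for cytotoxicity, read by CellTiter-Glo and resazurin assay, with a stated time of 72 h (on this read-out lower numbers stand for an effect already at smaller amounts and higher numbers for an effect only at larger amounts of compound), compound 1 gives > 24400 nM, which is a limit of the assay.
Compound 2, `CCOC(=O)CCCCCOc1cccc(CN(C(=O)c2ccc(-c3ccc4cc[nH]c4c3)cc2)C(C)C)c1`; compound 2 gives > 26000 nM, again a limit.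
Compound 3, `CCOC(=O)CCCCCOc1cccc(CN(C(=O)c2ccc(-c3cc(OC)ccc3F)cc2)C(C)C)c1`; compound 3 gives > 26000 nM, also a limit.

Going by the values given here, every value shown in this assay is a limit, so no compound stands above or below another. The three steps between them, a step that the two limits leave unreadable from compound 1 to compound 2, a step that the two limits leave unreadable from compound 1 to compound 3 and a step that the two limits leave unreadable from compound 2 to compound 3, cannot be sized. Compound 3 therefore stands where the whole series stands: at a limit, as recorded in the limit of > 24400 nM in this assay, at which 1 of the 3 values shown sits, and (the limit of > 26000 nM in this assay, at which 2 of the 3 values shown sit).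

The next compound is compound 4, `CCOC(=O)CCCCCOc1cccc(CN(C(=O)c2ccc(-c3cccc([N+](=O)[O-])c3)cc2)C(C)C)c1`. The change from compound 3 is 3-nitrophenyl in place of 2-fluoro-5-methoxyphenyl on an aromatic carbon. The measured steps that bear on it are the three exchanges of the aryl group listed above, and all of them are unreadable. No direction or size can be derived from them, and nothing in the data sets the nitrophenyl variant apart from the other aryl groups.

The expectation is therefore that compound 4 also reaches only a limit, with an expected step that the limit leaves unreadable from compound 3 to compound 4 not beyond the scatter. Compound 4 is estimated at 30000 nM, within 15000 nM to 100000 nM.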

Compound 4, half-maximal effective concentration: > 26000 nM
Compound 4: a limit, no number; the forecaster's own chance of this, stated with the estimate: 85%; the middle value does not contradict the limit.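

In this assay compound 4 gives > 26000 nM, which is a limit of the assay. The steps joining compound 4 to compound 1, compound 2 and compound 3 cannot be read, since all four values are limits. The compounds shown leave open whether any of these aryl groups on the shared core gives a measurable concentration in this assay, and how the four would rank.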